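The source may hold more compounds than are shown below. What is called first, only, known or untested is meant among the compounds shown, and "the series" means these compounds.

Compound 3 `O=C(Nc1ccc(Cl)c(-c2nnc3c(Cl)cccn23)c1)c1ccc(Cl)cc1Cl` stands at a limit in a functional assay on MDA-MB-231 cells (Homo sapiens) for antiproliferative activity, read by MTT assay, with stated times of 72 h and 4 h; on this read-out lower numbers stand for stronger inhibition and higher numbers for weaker inhibition: compound 3 gives > 100000 nM, which is a limit of the assay and not a number. Compound 1 `Cc1nc(C(=O)Nc2ccc(Cl)c(-c3nnc4c(Cl)cccn34)c2)cs1` likewise sits at a limit, giving > 100000 nM in this assay. Only compound 2 `O=C(Nc1ccc(Cl)c(-c2nnc3c(Cl)cccn23)c1)c1cccc(Cl)c1` returns a number, 66100 nM in this assay. The measured steps are accordingly thin: an at least 1.5-fold lower number from compound 1 to compound 2 (0.17 log units; that floor lies within the scatter), an at least 1.5-fold higher number from compound 2 to compound 3 (0.17 log units; that floor lies within the scatter) and a step that the two limits leave unreadable from compound 1 to compound 3, with the limit of > 100000 nM in this assay, at which 2 of the 3 values shown sit, bounding two of the three values. Compound 4 `CS(=O)(=O)c1cccc(C(=O)Nc2ccc(Cl)c(-c3nnc4c(Cl)cccn34)c2)c1` is obtained from compound 3 by 3-(methylsulfonyl)phenyl in place of 2,4-dichlorophenyl on a carbonyl carbon. Going by the values given here, none of the measured steps reaches beyond the scatter, so no step beyond the scatter is expected in this assay for this change either. Compound 4 is therefore estimated at 100000 nM, within 30000 nM to 300000 nM, an expected step of a number no higher from compound 3 to compound 4 (the limit leaves the size open).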

Compound 4, half-maximal inhibitory concentration: > 100000 nM
Compound 4 ended at the assay's limit; the forecaster's own chance of this, stated with the estimate: 60%; the middle value sits exactly at the limit.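

In this assay compound 4 gives > 100000 nM, which is a limit of the assay and not a number. Methylsulfonyl in place of chloro on an aromatic carbon gives an at least 1.5-fold higher number from compound 2 to compound 4 (0.17 log units; that floor lies within the scatter), so hydrogen-bond acceptors entering on this phenyl ring bring no readable gain. The steps to compound 4 from compound 1 and compound 3 cannot be read, and the limit now bounds most of the series: the limit of > 100000 nM in this assay, at which 3 of the 4 values shown sit.

From the compounds shown here alone, whether an amine or a carboxylic acid in place of the methylsulfonyl would return a number remains open.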